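Swapping the aryl group of compound 2

The compounds below may be only part of what the source reports. "The series", "measured", "known", "first", "only" and "open" are said of these compounds alone.

Compound 1 `Cc1oc(-c2ccccc2Cl)nc1CN1CCC(C(=O)NCCCN2C[C@H](C)C[C@H](C)C2)CC1`: 0.25 h
Compound 2 `Cc1ccc(-c2nc(CN3CCC(C(=O)NCCCN4C[C@H](C)C[C@H](C)C4)CC3)c(C)o2)cc1`: > 0.5 h
Compound 3 `COc1cccc(OC)c1-c1nc(CN2CCC(C(=O)NCCCN3C[C@H](C)C[C@H](C)C3)CC2)c(C)o1`: not yet measured

In an ADME assay on microsomes from liver (Rattus norvegicus) for metabolic stability, read by LC-MS, using NADPH, at 37 degrees C (on this read-out lower numbers stand for a shorter-lived compound and higher numbers for a longer-lived compound), compound 2 gives > 0.5 h, a limit of the assay and not a number. Compound 3 carries 2,6-dimethoxyphenyl in place of 4-methylphenyl on an aromatic carbon. Among the measured compounds shown here, the one measured step at this place is an at least 2.0-fold higher number from compound 1 to compound 2 (0.30 log units; that floor lies within the scatter), and it is a change of a different group. For the measured compounds named here, with only that step as a guide, and with compound 1 at 0.25 h, a modest drop is expected in this assay. The expected step is an at least 1.6-fold lower number from compound 2 to compound 3 (0.22 log units; that floor lies within the scatter). For compound 3 the estimate is 0.3 h, with an expected range of 0.15 h to 0.6 h.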

Compound 3, half-life: 0.2 h
For compound 3 the middle estimate is 1.5-fold (0.18 log units) above the measured one, within the range that was stated.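

In this assay this aryl position responds to the group it carries, with an at least 2.5-fold lower number from compound 2 to compound 3 (0.39 log units; beyond the scatter). Placing 2,6-dimethoxyphenyl where 2-chlorophenyl stood gives a 1.3-fold lower number from compound 1 to compound 3 (0.10 log units; within the scatter), so of the three groups only 4-methylphenyl stands apart. Compound 2 gives a limit and not a number, so the full size of its difference stays unknown: the limit of > 0.5 h in this assay, at which 1 of the 3 values shown sits.

From the compounds shown here alone, it remains open whether plain phenyl or a pyridyl group would behave like 4-methylphenyl or like the other two groups.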